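The source may hold more compounds than are shown below. What is called first, only, known or untested is meant among the compounds shown, and "the series" means these compounds.

The measured compounds:

compound 1, `CC#CC(CC(=O)O)c1ccc(OCc2ccc(C(=O)N3CCN(c4ccccc4)CC3)s2)cc1` — 72 nM
compound 2, `CC#CC(CC(=O)O)c1ccc(OCc2ccc(C(=O)N3CCN(c4cccnc4)CC3)s2)cc1` — 1140 nM
compound 3, `CC#CC(CC(=O)O)c1ccc(OCc2ccc(C(=O)N3CCN(c4ccccn4)CC3)s2)cc1` — 138 nM

In a functional assay on HEK293 cells for agonist activity at Free fatty acid receptor 1 (Homo sapiens), read by fluorescence and calcium flux (on this read-out lower numbers stand for an effect already at smaller amounts and higher numbers for an effect only at larger amounts of compound), compound 3 stands second highest of the three numbers. Its nearest neighbour is compound 1, with a 1.9-fold higher number from compound 1 to compound 3 (0.28 log units; within the scatter), a difference that stays within the scatter. Its furthest is compound 2, with an 8.3-fold lower number from compound 2 to compound 3 (0.92 log units; beyond the scatter), a step beyond the scatter; the step of a 16-fold higher number from compound 1 to compound 2 (1.20 log units; beyond the scatter) points the same way and is the largest seen here.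

Compound 4, `CC#CC(CC(=O)O)c1ccc(OCc2ccc(C(=O)N3CCN(c4cccc(F)c4)CC3)s2)cc1`, carries the change (3-fluorophenyl in place of pyridin-2-yl on an amine nitrogen in a ring). Among the measured compounds shown here, the step that bears on it most directly is the one from compound 1 to compound 3, since compound 1 already holds a plain phenyl at this position and gives 72 nM; that step lay within the scatter. The large steps involve pyridin-3-yl, which does not enter here. Compound 4 is therefore expected to sit close to compound 1 and compound 3, with an expected step of a 1.4-fold lower number from compound 3 to compound 4 (0.14 log units; within the scatter), not beyond the scatter. The estimate for compound 4 is 100 nM, within a range from 35 nM to 300 nM.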

Compound 4, half-maximal effective concentration: 97 nM
Estimate against measurement, compound 4: 1.0-fold (0.01 log units) above; the range from low to high includes it.
By their numbers in this assay, from the lowest: compounds 1, 4 and 3 (each within the scatter of the next); then compound 2.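

In this assay, the 3-fluorophenyl group fits the pattern of the plain phenyl group: fluoro in place of hydrogen gives a 1.3-fold higher number from compound 1 to compound 4 (0.13 log units; within the scatter), and 3-fluorophenyl in place of pyridin-2-yl gives a 1.4-fold lower number from compound 3 to compound 4 (0.15 log units; within the scatter). The replacement of pyridin-3-yl tells a different story, with a 12-fold lower number from compound 2 to compound 4 (1.07 log units; beyond the scatter), so among these four compounds only compound 2 stands beyond the scatter from all the others. Nothing available gives a reason for this separation.

The compounds shown leave open how a chloro, methoxy or nitrile group would read on the same aromatic ring, or a saturated cyclohexyl ring in place of that ring. With only compound 4 carrying fluoro, they also leave open whether the fluoro group would read the same elsewhere on the ring.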